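The source may hold more compounds than are shown below. What is called first, only, known or untested is meant among the compounds shown, and "the series" means these compounds.

Measured in an ADME assay on the whole organism (plasma, strain Sprague-Dawley) for pharmacokinetics, with Rattus norvegicus as the target, at a dose of 5 mg/kg by the oral route; on this read-out higher numbers stand for higher exposure at the dose given and lower numbers for lower exposure:
compound 1 `CON[C@]1(CCC(C)C)C(=O)C(C2=NS(=O)(=O)c3cc(NS(C)(=O)=O)ccc3N2)=C(O)c2ccccc21`: 350 ng.h/mL
compound 2 `CC(C)CC[C@@]1(NCc2ccccc2)C(=O)C(C2=NS(=O)(=O)c3cc(NS(C)(=O)=O)ccc3N2)=C(O)c2ccccc21`: 600 ng.h/mL
compound 3 `CC(C)(C)CCC1(NCc2ccc3ccccc3c2)C(=O)C(C2=NS(=O)(=O)c3cc(NS(C)(=O)=O)ccc3N2)=C(O)c2ccccc21`: 1020 ng.h/mL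

Compound 3 has the largest of the three numbers; its gap to compound 2 is within the scatter, its gap to compound 1 beyond it. Compound 4 `Cc1cccc(C)c1CNC1(CCC(C)(C)C)C(=O)C(C2=NS(=O)(=O)c3cc(NS(C)(=O)=O)ccc3N2)=C(O)c2ccccc21` differs from compound 3 by 2,6-dimethylphenyl in place of naphthalen-2-yl on a saturated chain carbon bound to an amine nitrogen. For the measured compounds named here, the only measured single-point step, a 1.7-fold higher number from compound 1 to compound 2 (0.23 log units; within the scatter), changes the group on the amine nitrogen itself and stays within the scatter; no measured step exchanges one aryl group for another on the saturated chain carbon bound to that nitrogen. On this basis no step beyond the scatter is expected for compound 4, with the wider uncertainty of an untested change. Compound 4 is estimated at 800 ng.h/mL (range 300 ng.h/mL to 2000 ng.h/mL), a step of a 1.3-fold lower number from compound 3 to compound 4 (0.11 log units; within the scatter).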

Compound 4, area under the concentration-time curve: 3500 ng.h/mL
Compound 4: the middle estimate sits 4.4-fold (0.64 log units) below what was measured; measured number outside the range, above it.
By their numbers in this assay, from the lowest: compounds 1, 2 and 3 (each within the scatter of the next, the first and the last beyond it); then compound 4.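

In this assay, for the compounds shown here, the aryl group on a saturated chain carbon bound to an amine nitrogen proves able to move exposure: 2,6-dimethylphenyl in place of naphthalen-2-yl gives a 3.4-fold higher number from compound 3 to compound 4 (0.54 log units; beyond the scatter) and is the only single-place step so far beyond the scatter. Going from two six-membered aromatic rings to one therefore does not cost exposure at this position. Nothing at hand accounts for the gain.

From the compounds shown here alone, whether the gain follows the two methyl groups or the single ring stays open. So does whether a pyridine ring in this place would keep the higher exposure.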